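The source may report more compounds than this note shows. Statements on the series, on what has been measured and on what is new or still open speak of the compounds shown alone.

Measured compounds:
- compound 1 `CC(O)c1cn([C@@H]2O[C@H](CO)[C@@H](O)[C@H]2O)nn1`, in a functional assay on MOLT-4 cells (Homo sapiens) (a higher number here means a weaker inhibitor, a lower number a stronger inhibitor), compound 1 gives > 200000 nM, a limit of this assay rather than a number.
- compound 2 `OC[C@H]1O[C@@H](n2cc(-c3ccc(F)cc3)nn2)[C@H](O)[C@@H]1O`, in this assay compound 2 gives 171000 nM.

Compound 2 therefore stands as the only number shown in this assay; the other value is a limit. Among the compounds with values here, the single measured step, an at least 1.1-fold lower number from compound 1 to compound 2 (0.06 log units; that floor lies within the scatter), swaps 4-fluorophenyl for 1-hydroxyethyl on an aromatic carbon, and its floor rests on (the limit of > 200000 nM in this assay, at which 1 of the 2 values shown sits), so it says little about size.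

Compound 3 `OC[C@H]1O[C@@H](n2cc(-c3ccsc3)nn2)[C@H](O)[C@@H]1O` has not been measured. It differs from compound 2 by thiophen-3-yl in place of 4-fluorophenyl on an aromatic carbon. No measured step involves this exchange, and the one step recorded is bounded by a limit, so nothing shown points to a shift in either direction beyond the scatter. Compound 3 is accordingly expected to show a 1.0-fold lower number from compound 2 to compound 3 (0.00 log units; within the scatter) relative to compound 2. The estimate for compound 3 in this assay is 170000 nM, within a range of 80000 nM to 350000 nM.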

Compound 3, half-maximal inhibitory concentration: 126000 nM
Compound 3: the middle estimate sits 1.3-fold (0.13 log units) above what was measured; measured number inside the range.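

On the aromatic carbon of the five-membered aromatic ring with 3 nitrogen, thiophen-3-yl in place of 4-fluorophenyl gives in this assay a 1.4-fold lower number from compound 2 to compound 3 (0.13 log units; within the scatter), so a one-ring aromatic group can change from a six-membered ring of carbon only to a five-membered ring with 1 hetero atom without a shift beyond the scatter. Within the data shown here, this is the first step at this position with a number at both ends, and it puts compound 2 and compound 3 on a level in this read-out. The step away from the 1-hydroxyethyl group reads an at least 1.5-fold lower number from compound 1 to compound 3 (0.20 log units; that floor lies within the scatter), which is a floor set by a limit and not a size, so it still does not show how far the aromatic groups stand from the 1-hydroxyethyl group: the limit of > 200000 nM in this assay, at which 1 of the 3 values shown sits.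

As far as these compounds go, it remains open whether any group on this carbon moves the number beyond the scatter, for instance a carboxylic acid, an aminomethyl group or a longer alkyl chain. From the compounds shown here alone, it also remains open whether a second ring joined to the aromatic group, or a substituent on the thiophen-3-yl ring, would do so.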